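Benzotriazole series: trimming the ring-nitrogen substituent

A few compounds are considered here, and "the series" means these few. Any claim that something is new, unique, unknown or untested is made for them only; others in the source may bear on it.

Measured so far:
compound 1 `Fc1cc(Cl)ccc1-c1ccc(Cn2nnc3ccccc32)cc1` — 28 nM
compound 2 `Brc1ccc(Cn2nnc3c(Br)cccc32)cn1` — 210 nM
compound 3 `Brc1cccc2c1nnn2CC1CC1` — 70 nM

Three compounds share the core and differ in the group attached to the ring nitrogen and in the substitution of the aromatic part. In a functional assay on cells for positive allosteric modulation of metabotropic glutamate receptor 2 (Homo sapiens), read by fluorescence and calcium flux, with a stated time of 30 min (a higher number here means that more compound is needed for the effect, a lower number that less compound is needed), compound 1 gives 28 nM, compound 2 gives 210 nM and compound 3 gives 70 nM. Compound 3 thus stands second highest of the three numbers: compound 1 sits a bit lower, beyond the scatter, and compound 2 sits higher, also beyond the scatter. No two of these compounds differ in a single place, so no step between measured compounds can be read off directly.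

Compound 4 `Cn1nnc2c(Br)cccc21` is the next compound to go into this assay. Relative to compound 3 the change is hydrogen in place of cyclopropyl on a saturated chain carbon bound to an aromatic nitrogen. Going by the values given here, nothing among the measured compounds covers this kind of truncation; compounds 1, 2 and 3 all carry a heavier group at that position, and compound 4 retains only the methyl. The expectation is a step toward a higher number, of a size beyond the scatter, estimated as a 7.1-fold higher number from compound 3 to compound 4 (0.85 log units; beyond the scatter). For compound 4 the value in this assay is expected around 500 nM, with a range from 150 nM to 2000 nM.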

Compound 4, half-maximal effective concentration: > 5000 nM
Compound 4 ended at the assay's limit; the forecaster's own chance of this, stated with the estimate: 15%; middle value at least 10-fold (1.00 log units) away from the limit.
By their numbers in this assay, from the lowest: compound 1; then compound 3; then compound 2. At a limit, above all of these: compound 4.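

Going by these compounds alone, compound 3 and compound 4 give the first pair that differs in one place, and the change of cyclopropylmethyl to methyl in this assay gives an at least 71-fold higher number from compound 3 to compound 4 (1.85 log units; beyond the scatter), a large step beyond the scatter. Within the data shown here, the earlier compounds showed only that quite different groups on a saturated chain carbon bound to an aromatic nitrogen all gave values within the measurable range; this pair shows that the position does not tolerate every change, since losing the cyclopropyl with its 3 heavy atoms takes the series out of that range. The value of compound 4 is a limit and not a number, so the step gives only a lower bound on the true size of the change: the limit of > 5000 nM in this assay, at which 1 of the 4 values shown sits.

As far as these compounds go, whether a chain between methyl and cyclopropylmethyl, such as ethyl or propyl, would bring the number back within the measurable range remains open. Equally open, from the compounds shown here alone, is whether the ring of the cyclopropyl matters as a ring, which an open chain such as isobutyl or a polar group such as an amine or a methoxyethyl on that carbon would begin to separate from simple size.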